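Thiazole to thiophene on the chloro-bearing core

The source may hold more compounds than are shown below. What is called first, only, known or untested is meant among the compounds shown, and "the series" means these compounds.

For the measured compounds named here, compound 3 `Cc1cc2nc(-c3nccs3)n(-c3cc4nc(N)nc(N)c4cc3Cl)c2cc1C` gives the lowest number of the three measured members. In an assay on isolated protein for inhibition of Dihydrofolate reductase (Homo sapiens), read by spectrophotometry, using NADPH, with a stated time of 10 min (on this read-out higher numbers stand for weaker inhibition and lower numbers for stronger inhibition), compound 3 gives 7.6 nM. Compound 1 `Cc1cc2nc(-c3nccs3)n(-c3ccc4c(N)nc(N)nc4c3)c2cc1C` gives 93 nM in this assay, and compound 2 `Cc1cc2nc(-c3cccs3)n(-c3ccc4c(N)nc(N)nc4c3)c2cc1C` gives 1030 nM. The step of a 12-fold lower number from compound 1 to compound 3 (1.09 log units; beyond the scatter) separates compound 3 from the nearest measured compound, and the gap to the most distant one, compound 2, is larger still.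

Compound 4 `Cc1cc2nc(-c3cccs3)n(-c3cc4nc(N)nc(N)c4cc3Cl)c2cc1C` is the next member. Relative to compound 3 it carries a single change: thiophen-2-yl in place of 1,3-thiazol-2-yl on an aromatic carbon.

The same exchange has been measured once, on the core that lacks the chloro group: an 11-fold higher number from compound 1 to compound 2 (1.04 log units; beyond the scatter). Going by the values given here, that step is the only direct precedent. The other measured step, a 12-fold lower number from compound 1 to compound 3 (1.09 log units; beyond the scatter), concerns the chloro group and does not bear on the present exchange except to set the starting point for compound 4.

On this basis the step from compound 3 to compound 4 is expected to be an 11-fold higher number from compound 3 to compound 4 (1.05 log units; beyond the scatter) in this assay, a rise of about the size seen once before. Compound 4 is therefore estimated to give 85 nM in this assay, with a range from 30 nM to 250 nM.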

Compound 4, inhibition constant: > 3000 nM
Compound 4 was reported as a limit (the forecaster's own chance of this, stated with the estimate: 2%); middle value at least 35-fold (1.54 log units) away from the limit.
By their numbers in this assay, from the lowest: compound 3; then compound 1; then compound 2. At a limit, above all of these: compound 4.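

The value of compound 4, > 3000 nM, is a limit and not a number, so the two steps that end on it are bounds. The exchange of 1,3-thiazol-2-yl for thiophen-2-yl, on an aromatic carbon between two ring nitrogen atoms, costs far more on the chloro-bearing core, an at least 390-fold higher number from compound 3 to compound 4 (2.59 log units; beyond the scatter), than on the core of compound 1, so the size of this change depends on the core that carries it: the same change on two cores in this assay, an 11-fold higher number (1.04 log units; beyond the scatter) from compound 1 to compound 2 and an at least 390-fold higher number (2.59 log units; beyond the scatter) from compound 3 to compound 4, at least 35-fold (1.55 log units) apart, beyond the scatter of two such steps

The chloro group also behaves differently with the two rings, giving an at least 2.9-fold higher number from compound 2 to compound 4 (0.46 log units; beyond the scatter) with thiophen-2-yl, against the drop seen with 1,3-thiazol-2-yl, so the two changes do not simply add: the same change on two cores in this assay, a 12-fold lower number (1.09 log units; beyond the scatter) from compound 1 to compound 3 and an at least 2.9-fold higher number (0.46 log units; beyond the scatter) from compound 2 to compound 4, at least 35-fold (1.55 log units) apart, beyond the scatter of two such steps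

On these data alone, the actual number for compound 4 stays open, and with it the full size of both steps. Also open, as far as these compounds go, is whether pyridin-2-yl or phenyl at this position would stay close to compound 3 at 7.6 nM on the chloro-bearing core, and whether fluoro or methyl in place of chloro would make the exchange as costly.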